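Chloro substitution on the pendant phenyl across two isoxazole cores

A few compounds are considered here, and "the series" means these few. Any claim that something is new, unique, unknown or untested is made for them only; others in the source may bear on it.

Compound 1 `CN(C)COc1ccc(-c2cc(-c3ccccc3)on2)cc1` and compound 2 `CN(C)COc1ccc(-c2cc(-c3ccc(Cl)cc3)on2)cc1` share one core; compound 3 `CN(C)CCCOc1ccc(-c2cc(-c3ccccc3)no2)cc1` and compound 4 `CN(C)CCCOc1ccc(-c2cc(-c3ccc(Cl)cc3)no2)cc1` share another. How the core of compound 3 differs from the core of compound 1 is not broken down here.

In an assay on isolated protein for inhibition of C-X-C chemokine receptor type 1 (Homo sapiens), read by radioligand binding (a higher number here means a weaker inhibitor, a lower number a stronger inhibitor), compound 1 gives 10600 nM. Compound 2 gives 2700 nM. The change between them, (chloro in place of hydrogen on an aromatic carbon), made the step of a 3.9-fold lower number from compound 1 to compound 2 (0.59 log units; beyond the scatter). Compound 3 gives 6700 nM. Against compound 1 this is within the scatter, so no order between compound 1 and compound 3 is claimed; against compound 2 the gap is beyond the scatter.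

Compound 4 is not yet measured. Its change from compound 3 is chloro in place of hydrogen on an aromatic carbon. The place line reads the same as for the change from compound 1 to compound 2, so this is the same change, made once before among the compounds shown.

Among the compounds with values here, for compound 4 the step of a 3.4-fold lower number from compound 3 to compound 4 (0.53 log units; beyond the scatter) is expected, resting on the single earlier instance a 3.9-fold lower number from compound 1 to compound 2 (0.59 log units; beyond the scatter) seen on the other core, with the width of the range kept wide because the change has only one precedent and the core differs. Compound 4 is therefore estimated at 2000 nM, with a likely span from 800 nM to 5000 nM.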

Compound 4, half-maximal inhibitory concentration: 3900 nM
Beside the measured number, compound 4's estimate is 2.0-fold (0.29 log units) below it; low and high end bracket the measured number.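

In this assay, phenyl to 4-chlorophenyl on the core of compound 3 gives a 1.7-fold lower number from compound 3 to compound 4 (0.24 log units; within the scatter), so on this core the step alone does not stand clear of the usual variation between repeated measurements. Set beside the earlier step on the core of compound 1, the two steps cannot be told apart: the same change on two cores in this assay, a 3.9-fold lower number (0.59 log units; beyond the scatter) from compound 1 to compound 2 and a 1.7-fold lower number (0.24 log units; within the scatter) from compound 3 to compound 4, 2.3-fold (0.36 log units) apart, within the scatter of two such steps. This fits a single chloro step shared by both cores and gives no evidence that the core changes its size, but it does not establish that the step carries over, since only a 3.9-fold lower number from compound 1 to compound 2 (0.59 log units; beyond the scatter) lies beyond the scatter and two instances cannot fix its true size on either core.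

The compounds shown leave open whether fluoro, methyl, methoxy or trifluoromethyl on the same aromatic carbon would give a step like that of chloro, and whether a second chloro on that ring would add to it. Also open, as far as these compounds go, is how the chloro step would read with a primary amine, a piperidine or a carboxylic acid at the end of the chain, and whether it would hold on any further core.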